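Replacing ethyl with cyano on the shared core

The source may report more compounds than this note shows. Statements on the series, on what has been measured and on what is new or still open speak of the compounds shown alone.

Three compounds share one core and differ only in the group on the outer six-membered ring. In an assay on CHO cells, read by calcium flux (a higher number here means a weaker inhibitor, a lower number a stronger inhibitor), compound 1 `CC(C)c1ccc(NC(=O)c2csc(Cc3c(Cl)cccc3Cl)n2)cc1` gives 520 nM, compound 2 `CC(C)(C)c1ccc(NC(=O)c2csc(Cc3c(Cl)cccc3Cl)n2)cc1` gives 300 nM, and compound 3 `CCc1ccc(NC(=O)c2csc(Cc3c(Cl)cccc3Cl)n2)cc1` gives 1450 nM, the highest of the three numbers. The steps of a 2.8-fold higher number from compound 1 to compound 3 (0.45 log units; beyond the scatter) and a 4.8-fold higher number from compound 2 to compound 3 (0.68 log units; beyond the scatter) show that trimming the group at this position raised the number each time, so the group here matters.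

Compound 4 `N#Cc1ccc(NC(=O)c2csc(Cc3c(Cl)cccc3Cl)n2)cc1` carries a different change: cyano in place of ethyl on an aromatic carbon. Within the data shown here, the two groups match in heavy-atom count, but cyano brings a triple bond and a hydrogen-bond acceptor that none of the measured compounds has, so the measured steps speak only of alkyl size and give no direction for this swap. In this assay compound 4 is therefore expected to land near compound 3, with the step of a 1.4-fold higher number from compound 3 to compound 4 (0.14 log units; within the scatter) estimated as small and uncertain, and the estimate for compound 4 is 2000 nM within a range of 600 nM to 7000 nM.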

Compound 4, half-maximal inhibitory concentration: 720 nM
The estimate for compound 4 lay 2.8-fold (0.44 log units) above the measured number; measured number inside the range.
By their numbers in this assay, from the lowest: compounds 2, 1, 4 and 3 (each within the scatter of the next, the first and the last beyond it).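

In this assay, the swap brings a 2.0-fold lower number from compound 3 to compound 4 (0.30 log units; within the scatter) and cyano in place of isopropyl brings a 1.4-fold higher number from compound 1 to compound 4 (0.14 log units; within the scatter), so a group with a triple bond and a hydrogen-bond acceptor sits on this aromatic carbon with a number that cannot be told apart from either alkyl neighbour, even though those two neighbours differ from each other beyond the scatter. Only tert-butyl stays clearly apart, with a 2.4-fold higher number from compound 2 to compound 4 (0.38 log units; beyond the scatter), so size among alkyl groups no longer describes this position on its own. Nothing measured here bears on why the nitrile reads as it does.

Open, as far as these compounds go, is how an amine, a methoxy group or a carboxylic acid would read on this same carbon. Also open, from the compounds shown here alone, is whether a group larger than tert-butyl, such as a cyclohexyl ring, would lower the number further.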